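Alkyl size against tolerated concentration in the series

The compounds below may be only part of what the source reports. "The series", "measured", "known", "first", "only" and "open" are said of these compounds alone.

Measured so far in an ADME assay on MT2 cells (Homo sapiens) for inhibition; a higher number here means that more compound is tolerated, a lower number that less compound is tolerated:
- compound 1 `Cc1cc(F)c(Cc2cnc(Nc3ccc(C#N)c(Cl)c3)o2)c(F)c1` gives 31000 nM
- compound 2 `CCc1cc(F)c(Cc2cnc(Nc3ccc(C#N)c(Cl)c3)o2)c(F)c1` gives 10000 nM
- compound 3 `CC(C)c1cc(F)c(Cc2cnc(Nc3ccc(C#N)c(Cl)c3)o2)c(F)c1` gives 5000 nM

Every enlargement of the alkyl group so far has lowered the number: a 3.1-fold lower number from compound 1 to compound 2 (0.49 log units; beyond the scatter), a 6.2-fold lower number from compound 1 to compound 3 (0.79 log units; beyond the scatter), while a 2.0-fold lower number from compound 2 to compound 3 (0.30 log units; within the scatter). Compound 3 therefore stands lowest of the three, separated from compound 1 beyond the scatter but not from compound 2.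

Compound 4 `N#Cc1ccc(Nc2ncc(Cc3c(F)cc(CC4CC4)cc3F)o2)cc1Cl` carries the next change, (cyclopropylmethyl in place of isopropyl on an aromatic carbon). The entering group is one heavy atom larger than the one it replaces, and the three steps above all bear on this direction of change, each giving a lower number as the group grew. A further modest step toward a lower number is therefore expected, of the order of a 1.7-fold lower number from compound 3 to compound 4 (0.22 log units; within the scatter), possibly no more than the scatter allows. For compound 4 the estimate in this assay is 3000 nM, with a range from 1200 nM to 8000 nM.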

Compound 4, half-maximal cytotoxic concentration: 29000 nM
For compound 4 the middle estimate is 9.7-fold (0.99 log units) below the measured one; the measured number lies above the stated range.
By their numbers in this assay, from the lowest: compounds 3 and 2 (each within the scatter of the next); then compounds 4 and 1 (each within the scatter of the next).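

In this assay added size at this position no longer goes with a lower number: cyclopropylmethyl, with 4 heavy atoms and one three-membered non-aromatic ring, gives a 5.8-fold higher number from compound 3 to compound 4 (0.76 log units; beyond the scatter) and a 2.9-fold higher number from compound 2 to compound 4 (0.46 log units; beyond the scatter). The lowering seen on going from methyl to ethyl and isopropyl therefore does not extend to every larger alkyl group, and compound 4 goes against it, standing level with the methyl compound (a 1.1-fold lower number from compound 1 to compound 4 (0.03 log units; within the scatter)). No measurement at hand accounts for this reversal.

Still open, as far as these compounds go, is whether the ring or the chain carbon carrying it sets the result, which a cyclopropyl group or an open isobutyl chain in place of cyclopropylmethyl would help separate. Also open, from the compounds shown here alone, is how an amine or a carboxylic acid on this aromatic carbon would read in this assay against these alkyl groups.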